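Moving from 3-methylphenyl to 2-methylphenyl on the piperazine arm

The compounds below may be only part of what the source reports. "The series", "measured", "known", "first", "only" and "open" are said of these compounds alone.

Two compounds of this series carry numbers in an assay on HEK293 cells for inhibition of Voltage-dependent T-type calcium channel subunit alpha-1G (Homo sapiens), read by fluorescence, tested at 10 uM; on this read-out lower numbers stand for less inhibition and higher numbers for more inhibition at the one concentration tested (going by the name of the read-out). Compound 1 `CCCc1nc(-c2ccccc2)c(CNCCCN2CCN(c3cccc(C)c3)CC2)o1` gives 47.8% in this assay, the lowest of the two numbers. Compound 2 `CCCc1nc(-c2ccccc2)c(CNCCN2CCN(c3cccc(C(F)(F)F)c3)CC2)o1` gives 56.3% in this assay, a figure that lies within the scatter of the value of compound 1, so the two cannot be ordered. For the measured compounds named here, compound 2 also differs from compound 1 in more than one place, so no single step between measured compounds is available to guide the next move.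

Compound 3 `CCCc1nc(-c2ccccc2)c(CNCCCN2CCN(c3ccccc3C)CC2)o1` has the same atoms as compound 1, joined differently: 2-methylphenyl in place of 3-methylphenyl on an amine nitrogen in a ring. Going by the values given here, no measured pair in this set shows what such a change does in this assay, so the expectation rests on the two numbers alone. The expected step of a number 1.8 percentage points lower from compound 1 to compound 3 (within the scatter) is small and stays within the scatter, with no direction claimed beyond it. Compound 3 is estimated at 46%, with a range from 26% to 66%. This estimate sits near compound 1 at 47.8%, and the width of the range reflects the absence of any measured step of this kind.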

Compound 3, a percentage reported as inhibition, at one concentration (the size of the read-out at that concentration, not a potency): 54.5%
Beside the measured number, compound 3's estimate is 8.5 percentage points below it; low and high end bracket the measured number.
By their numbers in this assay, from the lowest: compounds 1, 3 and 2 (each within the scatter of the next).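

In this assay, the series now has its first step that can be read at a single place: 2-methylphenyl in place of 3-methylphenyl on an amine nitrogen in a ring gives a number 6.7 percentage points higher from compound 1 to compound 3 (within the scatter). Unlike compound 1 and compound 2, which differ in more than one place, this pair isolates where the methyl group sits on the phenyl ring while the rest of the structure stays the same, and on this read-out the exchange does not separate the two compounds. No measurement at hand speaks to what lies behind this step.

The compounds shown leave open whether a methoxy group or a chlorine atom in place of the methyl group of 2-methylphenyl would give a step beyond the scatter at this position. They also leave the contributions of the chain and the aryl group of compound 2 unseparated, and pairing the trifluoromethyl-bearing aryl group of compound 2 with the chain of compound 1 would provide single-place steps for both.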